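A Chlorine Added to a Sulfonamide Already at the Limit

The source may report more compounds than this note shows. Statements on the series, on what has been measured and on what is new or still open speak of the compounds shown alone.

Of the compounds shown here, three built on a shared core have been measured in an assay on cells for inhibition of HSP60/HSP10 (Homo sapiens), with a stated time of 60 min; a higher number here means a weaker inhibitor, a lower number a stronger inhibitor. Compound 1 `N#Cc1ccc(S(=O)(=O)Nc2ccc(-c3nc4cc(NS(=O)(=O)c5ccc(C#N)cc5)ccc4o3)cc2)cc1` gives 49000 nM. For compound 2 `O=S(=O)(Nc1ccc2oc(-c3ccccc3)nc2c1)c1ccc(Cl)c(Cl)c1` the assay reports only a limit, > 100000 nM. For compound 3 `COc1ccc(S(=O)(=O)Nc2ccc(-c3nc4ccccc4o3)cc2)cc1` the assay likewise reports only a limit, > 100000 nM. Compound 3 thus stands at the edge of what this assay can measure, where (the limit of > 100000 nM in this assay, at which 2 of the 3 values shown sit). Nothing more precise is known of how strongly compound 3 inhibits.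

Compound 4 `COc1ccc(Cl)cc1S(=O)(=O)Nc1ccc(-c2nc3ccccc3o2)cc1` has not been measured yet. It differs from compound 3 in one place: 5-chloro-2-methoxyphenyl in place of 4-methoxyphenyl on a sulfonyl sulfur. For the measured compounds named here, no pair of measured compounds differs in this way, so no size for such a change can be read from the numbers. The step from compound 3 to compound 4 is expected to be none beyond the scatter, and a number no higher from compound 3 to compound 4 (the limit leaves the size open) is the estimated step. For compound 4 the expected value in this assay is 100000 nM, with a range from 30000 nM to 300000 nM, and a limit rather than a number is the likelier report.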

Compound 4, half-maximal inhibitory concentration: > 100000 nM
Compound 4: no number, only a limit; the forecaster's own chance of this, stated with the estimate: 65%; the middle value sits exactly at the limit.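

For the compounds shown here, compound 3 and compound 4 both return only a limit in this assay, so no step between them can be read: the limit of > 100000 nM in this assay, at which 3 of the 4 values shown sit. The compounds shown leave open whether 5-chloro-2-methoxyphenyl in place of 4-methoxyphenyl on a sulfonyl sulfur changes inhibition at all.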